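From 4-Chlorophenyl to 3-Chloro-4-fluorophenyl on Compound 3

The compounds below may be only part of what the source reports. "The series", "measured", "known", "first", "only" and "open" are said of these compounds alone.

Of the compounds shown here, three sharing one core have been measured in a functional assay on HT-29 cells (Homo sapiens) for antiproliferative activity, read by MTT assay, with a stated time of 72 h; on this read-out lower numbers stand for stronger inhibition and higher numbers for weaker inhibition. Compound 1 `CNC(=O)c1cc(Oc2ccc(NC(=O)c3cc4cccnc4n(-c4ccccc4)c3=O)cc2)ccn1` gives 250 nM. Compound 2 `CNC(=O)c1cc(Oc2ccc(NC(=O)c3cc4cccnc4n(-c4ccc(Cl)cc4)c3=O)cc2)ccn1` gives 390 nM, and compound 3 `CCNC(=O)c1cc(Oc2ccc(NC(=O)c3cc4cccnc4n(-c4ccc(Cl)cc4)c3=O)cc2)ccn1` gives 330 nM. Compound 3 therefore holds the second highest of the three numbers, nearest to compound 2 and furthest from compound 1, yet all three values lie within the usual scatter of one another, so no order among them can be claimed.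

Compound 4 `CCNC(=O)c1cc(Oc2ccc(NC(=O)c3cc4cccnc4n(-c4ccc(F)c(Cl)c4)c3=O)cc2)ccn1` differs from compound 3 in one place: 3-chloro-4-fluorophenyl in place of 4-chlorophenyl on an aromatic nitrogen. Among the measured compounds shown here, two measured steps bear on this change. The step of a 1.6-fold higher number from compound 1 to compound 2 (0.19 log units; within the scatter) placed a halogen on this same aromatic ring and stayed within the scatter. The step of a 1.2-fold lower number from compound 2 to compound 3 (0.07 log units; within the scatter) concerned a different part of the molecule and likewise stayed within the scatter. Neither step gives ground for expecting the added fluorine to move the number beyond the scatter in either direction. Compound 4 is therefore expected to give about 350 nM in this assay, with a range from 150 nM to 800 nM. This expectation corresponds to a 1.1-fold higher number from compound 3 to compound 4 (0.03 log units; within the scatter), that is, no step beyond the scatter.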

Compound 4, half-maximal inhibitory concentration: 2600 nM
The estimate for compound 4 lay 7.4-fold (0.87 log units) below the measured number; measured number above the stated range.
By their numbers in this assay, from the lowest: compounds 1, 3 and 2 (each within the scatter of the next); then compound 4.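

In this assay, the change from 4-chlorophenyl to 3-chloro-4-fluorophenyl on the aromatic nitrogen gives a 7.9-fold higher number from compound 3 to compound 4 (0.90 log units; beyond the scatter), the only step shown that goes beyond the scatter, and the higher number stands for weaker inhibition. Among the compounds shown here, this position therefore does not tolerate every halogen pattern equally: placing a chloro on the same ring gave only a 1.6-fold higher number from compound 1 to compound 2 (0.19 log units; within the scatter), which stayed within the scatter, so the earlier compounds had hidden any sensitivity to the substitution here. No measurement shown explains why this change raises the number so much more than the earlier one did.

The one step alters the halogen pattern in two ways, as a fluorine enters and the chlorine no longer matches that of the 4-chlorophenyl group, so the compounds shown leave open which of these goes with the higher number, and whether the same change would have a similar size on the methyl amide of compound 2. They also leave open how this position would respond to a group other than a halogen, such as a methoxy group or an amine on the same ring.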